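Acetylpiperazine amide at the terminal carbonyl of compound 3

This account rests on a few compounds, and the source may have more. Where it says the series, first, only, none or still open, it means among the compounds named here.

Compound 1 `CCCCCCCCN(C)C(=O)Cn1cc(Cc2cnc(=O)n(CC(=O)O)c2)c(=O)nc1SCc1ccc(F)cc1`: 27%
Compound 2 `CCCCCCCCN(C)C(=O)Cn1cc(Cc2cnc(=O)n(CCO)c2)c(=O)nc1SCc1ccc(F)cc1`: 36%
Compound 3 `CCCCCCCCN(C)C(=O)Cn1cc(Cc2cnc(=O)n(CC(=O)NCCO)c2)c(=O)nc1SCc1ccc(F)cc1`: 40%

Three compounds of this series were measured in a functional assay on a cell-free system (plasma, Oryctolagus cuniculus) for inhibition of platelet-activating factor acetylhydrolase (Homo sapiens), tested at 100 nM; on this read-out higher numbers stand for more inhibition at the one concentration tested (going by the name of the read-out) and lower numbers for less inhibition. Compound 3 carries the highest number of the three, though its step from compound 2, a number 4 percentage points higher from compound 2 to compound 3 (within the scatter), is within the scatter, so the two cannot be told apart; only its step from compound 1, a number 13 percentage points higher from compound 1 to compound 3 (beyond the scatter), is beyond it. The step of a number 9 percentage points higher from compound 1 to compound 2 (within the scatter) is also within the scatter.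

Compound 4 `CCCCCCCCN(C)C(=O)Cn1cc(Cc2cnc(=O)n(CC(=O)N3CCN(C(C)=O)CC3)c2)c(=O)nc1SCc1ccc(F)cc1` differs from compound 3 in one place: 4-acetylpiperazin-1-yl in place of (2-hydroxyethyl)amino on a carbonyl carbon. For the measured compounds named here, the only measured step at the same carbonyl carbon is a number 13 percentage points higher from compound 1 to compound 3 (beyond the scatter), a modest gain, and that compared hydroxy with (2-hydroxyethyl)amino rather than with a ring. Going by the values given here, no measured pair shows what 4-acetylpiperazin-1-yl does here. The changes at this end of the molecule have so far moved the numbers little, so for compound 4 a step of a number 2 percentage points lower from compound 3 to compound 4 (within the scatter) is expected in this assay, not beyond the scatter in either direction. Compound 4 is therefore estimated at 38%, within a range from 22% to 54%.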

Compound 4, a percentage reported as inhibition, at one concentration (the size of the read-out at that concentration, not a potency): 49%
Beside the measured number, compound 4's estimate is 11 percentage points below it; the range from low to high includes it.
By their numbers in this assay, from the lowest: compounds 1, 2, 3 and 4 (each within the scatter of the next, the first and the last beyond it).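

With 4-acetylpiperazin-1-yl on the carbonyl carbon, this position is shown to accept a six-membered non-aromatic ring in place of the open (2-hydroxyethyl)amino chain and to give up that chain's hydrogen-bond donors, while compound 3 and compound 4 cannot be told apart (a number 9 percentage points higher from compound 3 to compound 4 (within the scatter)) in this assay. The ring amide also clears the scatter against the hydroxymethyl compound (a number 13 percentage points higher from compound 2 to compound 4 (beyond the scatter)), which compound 3 did not do, and it stands further from the carboxylic acid than any earlier compound did (a number 22 percentage points higher from compound 1 to compound 4 (beyond the scatter)), though that step remains modest. Nothing at hand explains these differences in the numbers.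

On these data alone, whether the piperazine ring or its acetyl group matters more stays open, and an unsubstituted piperazin-1-yl, a morpholin-4-yl or a dimethylamino group on the same carbonyl carbon would help to separate the two. As far as these compounds go, as each number comes from a single concentration, the potencies of all four compounds also remain open, as does the question of whether the order among them would hold at other concentrations.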